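The source may hold more compounds than are shown below. What is called first, only, known or untested is meant among the compounds shown, and "the series" means these compounds.

Working notes on the series. Compound 1 `Cc1csc(NC(=O)c2cccc(Cl)c2)n1` and compound 2 `Cc1cccc(NC(=O)c2cccc(C(F)(F)F)c2)n1` share the amide linkage but differ in both rings. In an assay on membranes from brain for binding affinity to metabotropic glutamate receptor 5 (Rattus norvegicus) (a lower number here means a stronger inhibitor, a higher number a weaker inhibitor), compound 1 gives 5490 nM. In this assay compound 2 gives 18700 nM, the higher of the two numbers. Compound 3 `Cc1cccc(NC(=O)c2cccc(Oc3ccccc3)c2)n1` differs from compound 2 by phenoxy in place of trifluoromethyl on an aromatic carbon. Within the data shown here, no measured pair shows this change, so the size of the step is open. The step from a 2.3-fold lower number from compound 2 to compound 3 (0.37 log units; beyond the scatter) is expected to stay within the scatter or be a modest gain. Compound 3 is estimated at 8000 nM, with a range of 2000 nM to 40000 nM.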

Compound 3, half-maximal inhibitory concentration: 57000 nM
Beside the measured number, compound 3's estimate is 7.1-fold (0.85 log units) below it, outside the stated range (above it).
By their numbers in this assay, from the lowest: compound 1; then compound 2; then compound 3.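

Phenoxy in place of trifluoromethyl on this aromatic carbon gives a 3.0-fold higher number from compound 2 to compound 3 (0.48 log units; beyond the scatter) in this assay, the first change in the series that can be read at a single place. On this one pair, the larger group with its added aromatic ring moves the number in the weaker direction, so a bigger substituent at this position brings no gain. Nothing in hand accounts for the step.

From the compounds shown here alone, whether a methoxy group or an amine at the same place would give a lower number than compound 2 stays open. Going by these compounds, whether the step would carry over to the core of compound 1 also stays open.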